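The source may hold more compounds than are shown below. What is called first, only, known or untested is meant among the compounds shown, and "the series" means these compounds.

Of the compounds shown here, three have been measured in a functional assay on CHO-K1 cells for antagonist activity at Orexin/Hypocretin receptor type 1 (Homo sapiens), read by FLIPR and calcium flux; a higher number here means a weaker inhibitor, a lower number a stronger inhibitor. Among the measured compounds shown here, compound 1 `CCOC(=O)c1ccccc1C(=O)N1C[C@H](Oc2cc(C#N)ccn2)CC[C@H]1C` gives 7100 nM, and compound 2 `CC(C)OC(=O)c1ccccc1C(=O)N1C[C@H](Oc2cc(C#N)ccn2)CC[C@H]1C` gives 3300 nM; the step of a 2.2-fold lower number from compound 1 to compound 2 (0.33 log units; beyond the scatter) is the only measured pair that differs in a single place. Compound 3 `CCc1ccnc(O[C@@H]2CC[C@@H](C)N(C(=O)c3ccccc3-n3nccn3)C2)c1` gives 310 nM, the lowest of the three numbers, and its gaps to compound 2 and to compound 1 both lie beyond the scatter. Compound 4 `COC(=O)c1ccnc(O[C@@H]2CC[C@@H](C)N(C(=O)c3ccccc3-n3nccn3)C2)c1` differs from compound 3 in one place: methoxycarbonyl in place of ethyl on an aromatic carbon. For the measured compounds named here, the one measured step concerns an ester on another part of the shared core, so no measured step bears directly on this change. Resting on compound 3 alone, the expected step is a 3.2-fold higher number from compound 3 to compound 4 (0.51 log units; beyond the scatter), toward a weaker inhibitor. Compound 4 is therefore estimated at 1000 nM, with a range from 250 nM to 4000 nM.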

Compound 4, half-maximal inhibitory concentration: 1800 nM
Beside the measured number, compound 4's estimate is 1.8-fold (0.26 log units) below it, within the range that was stated.
By their numbers in this assay, from the lowest: compound 3; then compounds 4 and 2 (each within the scatter of the next); then compound 1.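

At the aromatic carbon opposite the ring nitrogen, methoxycarbonyl in place of ethyl gives a 5.8-fold higher number from compound 3 to compound 4 (0.76 log units; beyond the scatter) in this assay. Among the compounds shown here, this is the first measured change at this position, and it shows that the number responds to the group placed there, with the ester giving a weaker inhibitor than ethyl. No evidence on the reason for this step is available. As far as these compounds go, whether hydrogen, methyl, a longer chain, an amine or a carboxylic acid on this carbon would give a lower or higher number stays open.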